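The compounds below may be only part of what the source reports. "The series", "measured", "known", "first", "only" and "open" are said of these compounds alone.

Measured so far in an ADME assay on MCF-10A cells (Homo sapiens) for cytotoxicity, read by CCK-8 assay and cell counting, with a stated time of 72 h; on this read-out higher numbers stand for weaker inhibition and lower numbers for stronger inhibition:
Compound 1 `COc1ccc(-c2cc3ccccc3c(-c3cccc(N)c3)n2)cc1` gives 18800 nM.
Compound 2 `COc1ccc(-c2cc3ccccc3c(-c3ccc(O)cc3)n2)cc1` reaches only a limit of the assay, > 50000 nM.
Compound 3 `COc1ccc(-c2cc3cc(C)ccc3c(-c3cccc(N)c3)n2)cc1OC` gives 5600 nM.

Compound 4 `COc1ccc(-c2cc3cc(C)ccc3c(-c3ccc(O)cc3)n2)cc1OC` has not yet been measured in this assay.

Between the measured pair, the change is 4-hydroxyphenyl in place of 3-aminophenyl on an aromatic carbon. It produced an at least 2.6-fold higher number from compound 1 to compound 2 (0.42 log units; beyond the scatter); the upper end of that step is open, as compound 2 sits at the limit of > 50000 nM in this assay, at which 1 of the 3 values shown sits. The same change, (4-hydroxyphenyl in place of 3-aminophenyl on an aromatic carbon), separates compound 4 from compound 3. How the core of compound 3 differs from the core of compound 1 is not broken down here. The surroundings of the place are not worded identically either: in compound 1 the place is meta to a 4-methoxyphenyl group (8 heavy atoms), in compound 3 it is meta to a large group, so this is the same kind of change rather than the same change.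

From compound 3 to compound 4 a step of about a 3.6-fold higher number from compound 3 to compound 4 (0.55 log units; beyond the scatter) is expected in this assay, set beside the measured step, and resting on compound 3 at 5600 nM. Compound 4 is therefore estimated at 20000 nM, plausibly between 8000 nM and 50000 nM.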

Compound 4, half-maximal inhibitory concentration: 18100 nM
Compound 4: middle estimate off by 1.1-fold (0.04 log units), on the high side; low and high end bracket the measured number.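

In this assay, putting 4-hydroxyphenyl in place of 3-aminophenyl on the core of compound 3 gives a 3.2-fold higher number from compound 3 to compound 4 (0.51 log units; beyond the scatter) and so weakens inhibition, as the same change did on the core of compound 1. Set side by side, the two steps read: the same change on two cores in this assay, an at least 2.6-fold higher number (0.42 log units; beyond the scatter) from compound 1 to compound 2 and a 3.2-fold higher number (0.51 log units; beyond the scatter) from compound 3 to compound 4; the limit leaves it open whether they differ. On these data alone, compound 2 gives only a limit and not a number, so the direction of the change carries over from one core to the other in this pair of steps, but whether its size carries over stays unknown: the limit of > 50000 nM in this assay, at which 1 of the 4 values shown sits.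

Each step changes two things at once, the group itself and its numbered position in the name, from 3-aminophenyl to 4-hydroxyphenyl, and the compounds shown leave open which of the two drives the weaker inhibition. A 3-hydroxyphenyl or a 4-aminophenyl group at the same place on either core would pull these two apart.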